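The source may hold more compounds than are shown below. What is called first, only, known or untested is meant among the compounds shown, and "the series" means these compounds.

Compound 3 `COc1ccc(-c2cnc(NC(=O)c3ccccc3C#N)n2C)cc1` is one of three close relatives tested in a toxicity assay on THP-1 cells (Homo sapiens) for inhibition; a lower number here means that less compound is tolerated, a higher number that more compound is tolerated. In this assay compound 3 gives > 100000 nM, which is a limit of the assay rather than a measured number. Compound 1 `COc1ccc(-c2cnc(NC(=O)c3ccc(F)cc3)n2C)cc1` likewise gives >= 50000 nM, again a limit. Compound 2 `COc1ccc(-c2cnc(NC(=O)c3ccc(O)cc3)n2C)cc1` gives > 100000 nM, also a limit. Because every value sits at the limit of > 100000 nM in this assay, at which 2 of the 3 values shown sit, or at the limit of >= 50000 nM in this assay, at which 1 of the 3 values shown sits, none of the steps between them can be read: the step from compound 1 to compound 3 is a step that the two limits leave unreadable from compound 1 to compound 3, and the step from compound 2 to compound 3 is a step that the two limits leave unreadable from compound 2 to compound 3.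

The next compound, compound 4 `COc1ccc(-c2cnc(NC(C)=O)n2C)cc1`, changes the same position once more: methyl in place of 2-cyanophenyl on a carbonyl carbon. The two steps that touch that position give no readable size, so no step beyond the scatter can be expected in either direction. Compound 4 is therefore expected to sit at about 100000 nM, estimated between 40000 nM and 300000 nM, meaning an expected step of a number no higher from compound 3 to compound 4 (the limit leaves the size open), most likely reported again only as a limit.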

Compound 4, half-maximal cytotoxic concentration: > 100000 nM
Compound 4 ended at the assay's limit (the forecaster's own chance of this, stated with the estimate: 85%); the middle value lies on the limit itself.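

In this assay, within the data shown here, compound 4 gives > 100000 nM, which is a limit and not a number, and no step from compound 1, compound 2 or compound 3 to compound 4 can be read. The compounds shown leave open at what concentration each becomes toxic, and whether the group on the carbonyl carbon matters.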